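The source may report more compounds than this note shows. Statements on the series, on what has been measured and on what is new or still open speak of the compounds shown alone.

Measured in a functional assay on PC-3 cells (Homo sapiens) for antiproliferative activity, read by MTT assay, with a stated time of 24 h; on this read-out lower numbers stand for stronger inhibition and higher numbers for weaker inhibition:
- Compound 1 `CCn1c(C(=O)NCCNC(=O)OC(C)(C)C)ccc1C(CC)(CC)c1ccc(OCS(=O)(=O)c2ccccc2)c(C)c1`: > 50000 nM, a limit of the assay and not a number
- Compound 2 `CCn1c(C(=O)NCCC(=O)O)ccc1C(CC)(CC)c1ccc(OCS(=O)(=O)c2ccccc2)c(C)c1`: 14400 nM

Among the measured compounds shown here, compound 2 holds the only real number in this assay. Compound 3 `CCn1c(C(=O)N[C@@H](CCC(=O)O)C(=O)O)ccc1C(CC)(CC)c1ccc(OCS(=O)(=O)c2ccccc2)c(C)c1` keeps the shared core and carries 1,3-dicarboxypropyl in place of 2-carboxyethyl on an amide-type nitrogen. For the measured compounds named here, one measured step bears on this change: an at least 3.4-fold lower number from compound 1 to compound 2 (0.54 log units; beyond the scatter). Going by these compounds, that step brought in a carboxy group and lies beyond the scatter, but its full size is unknown, and it replaced a different group from the one changing now. It therefore offers only loose guidance, and no large move is expected. The expected result is a 1.3-fold higher number from compound 2 to compound 3 (0.10 log units; within the scatter), a small step with no firm direction. For compound 3 the estimate is 18000 nM, with an expected range of 5000 nM to 50000 nM.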

Compound 3, half-maximal inhibitory concentration: > 50000 nM
Compound 3 ended at the assay's limit; the forecaster's own chance of this, stated with the estimate: 25%; at least 2.7-fold (0.44 log units) between middle value and limit.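

On the amide-type nitrogen, 1,3-dicarboxypropyl in place of 2-carboxyethyl gives an at least 3.4-fold higher number from compound 2 to compound 3 (0.54 log units; beyond the scatter) in this assay, so this position responds to a change that keeps a carboxy group on the chain and brings in a second one. Going by these compounds, compound 3 gives > 50000 nM, which is a limit of the assay and not a number, so the full size of this step is unknown. The step from compound 1 to compound 3 cannot be read, and most of this small set sits at the edge of the read-out: the limit of > 50000 nM in this assay, at which 2 of the 3 values shown sit.

On these data alone, whether the weaker inhibition goes with the second carboxy group, the larger chain or the defined stereocentre stays open. A 3-carboxypropyl or a 1-carboxypropyl group on the same nitrogen, each with a single carboxy group, would help to tell these apart.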